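Removing the Methoxy Group from Compound 3

The compounds below may be only part of what the source reports. "The series", "measured", "known", "first", "only" and "open" are said of these compounds alone.

Compound 3 `CCC(=O)Nc1cccc(Oc2nc(Nc3ccc(N4CCC(C)CC4)cc3OC)ncc2Cl)c1` gives 9.2% in an assay on isolated protein for inhibition of NUAK family SNF1-like kinase 1 (Homo sapiens), read by ADP-Glo, with a stated time of 60 min, tested at 10 uM, in the presence of a further agent that is not named here (a higher number here means more inhibition at the concentration tested (going by the name of the read-out), a lower number less inhibition), the lowest of the three measured numbers. Among the measured compounds shown here, compound 2 `CCC(=O)Nc1cccc(Oc2nc(Nc3ccc(N4CCC(OC)CC4)cc3)ncc2Cl)c1` gives 86.5% and compound 1 `CCC(=O)Nc1cccc(Oc2nc(Nc3ccc(N4CCN(C)CC4)cc3)ncc2Cl)c1` gives 92.9%; the only measured step, a number 6.4 percentage points lower from compound 1 to compound 2 (within the scatter), lies within the scatter. Compound 4 `CCC(=O)Nc1cccc(Oc2nc(Nc3ccc(N4CCC(C)CC4)cc3)ncc2Cl)c1` differs from compound 3 by hydrogen in place of methoxy on an aromatic carbon. For the measured compounds named here, no measured step covers this change directly: compounds 1 and 2 lack the methoxy but carry 4-methylpiperazin-1-yl or 4-methoxypiperidin-1-yl instead of 4-methylpiperidin-1-yl, so two features differ at once. A large upward step is expected because compound 1 gives 92.9% and compound 2 gives 86.5% without the methoxy. Compound 4 is estimated at 80%, with a range from 40% to 95%, an expected step of a number 70.8 percentage points higher from compound 3 to compound 4 (beyond the scatter).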

Compound 4, a percentage reported as inhibition, at one concentration (the size of the read-out at that concentration, not a potency): 13.4%
Compound 4: the middle estimate sits 66.6 percentage points above what was measured; measured number outside the range, below it.
By their numbers in this assay, from the lowest: compounds 3 and 4 (each within the scatter of the next); then compounds 2 and 1 (each within the scatter of the next).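

In this assay, hydrogen in place of methoxy on this aromatic carbon leaves a step that does not stand out from the scatter, a number 4.2 percentage points higher from compound 3 to compound 4 (within the scatter), so the low number does not depend on that methoxy. The large steps lie at the other end of the molecule: with methyl in place of methoxy on a saturated ring carbon, a number 73.1 percentage points lower from compound 2 to compound 4 (beyond the scatter), and with 4-methylpiperidin-1-yl in place of 4-methylpiperazin-1-yl, a number 79.5 percentage points lower from compound 1 to compound 4 (beyond the scatter). No measurement at hand gives a reason for these large steps. Going by these compounds, what remains open is how a hydroxyl group or an amine would compare with methyl on that saturated ring carbon, and what methoxy on the aromatic carbon would do alongside 4-methylpiperazin-1-yl.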